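A few compounds are considered here, and "the series" means these few. Any claim that something is new, unique, unknown or untested is made for them only; others in the source may bear on it.

In an ADME assay on L6 cells (Rattus norvegicus) for cytotoxicity, read by resazurin assay, with a stated time of 72 h (on this read-out higher numbers stand for weaker inhibition and lower numbers for stronger inhibition), two compounds sharing a core have been measured so far. Compound 1 `NC1CC2(N3CCCC3)CC(c3ccccc3)C1C(c1ccccc1)C2`, with amino on a saturated ring carbon, gives 38100 nM. Compound 2 `O=C(CN1CCCCC1)OC1CC2(N3CCCC3)CC(c3ccccc3)C1C(c1ccccc1)C2`, with (((piperidin-1-yl)methyl)carbonyl)oxy at that place, gives 14200 nM, the lower of the two numbers.

Compound 3 `NCC(=O)OC1CC2(N3CCCC3)CC(c3ccccc3)C1C(c1ccccc1)C2` has not yet been measured. It differs from compound 2 at the far end of that group: amino in place of piperidin-1-yl on a saturated chain carbon bound to a carbonyl carbon. The group thus becomes ((aminomethyl)carbonyl)oxy.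

Going by the values given here, only one measured step offers any guide, and it is an indirect one. That step, a 2.7-fold lower number from compound 1 to compound 2 (0.43 log units; beyond the scatter), is modest but lies beyond the scatter. Among the compounds with values here, it exchanged the whole group on the ring carbon, so it bears only loosely on this smaller change, and no measured pair makes the same exchange. The expected move is therefore small and upward, and it may not clear the scatter: a 1.7-fold higher number from compound 2 to compound 3 (0.23 log units; within the scatter). In this assay, the estimate for compound 3 is 24000 nM, with an expected range from 9000 nM to 60000 nM.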

Compound 3, half-maximal inhibitory concentration: 42900 nM
The estimate for compound 3 lay 1.8-fold (0.25 log units) below the measured number, within the range that was stated.
By their numbers in this assay, from the lowest: compound 2; then compounds 1 and 3 (each within the scatter of the next).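

In this assay, the far end of the group on the ring carbon turns out to matter: amino in place of piperidin-1-yl on a saturated chain carbon bound to a carbonyl carbon gives a 3.0-fold higher number from compound 2 to compound 3 (0.48 log units; beyond the scatter), a modest step but a real one. The earlier compounds shown here could not separate the carbonyl-oxy link from what it carries, and here ((aminomethyl)carbonyl)oxy in place of amino on the saturated ring carbon gives a 1.1-fold higher number from compound 1 to compound 3 (0.05 log units; within the scatter), so that link with an amino end does not by itself bring the number down. Among these three compounds, then, only compound 2, which carries the piperidin-1-yl end, stands apart from the others, and no measurement on hand says what lies behind this difference.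

These compounds cannot tell whether the lower number of compound 2 needs the ring, its nitrogen or both, which a cyclohexyl end without nitrogen, an open-chain dimethylamino end or a morpholin-4-yl end would help to separate. Also open, from the compounds shown here alone, is how a longer chain between the carbonyl and the piperidin-1-yl end, or an amide in place of the ester link, would change the number on this read-out.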